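The source may report more compounds than this note shows. Statements on the series, on what has been measured and on what is new or still open speak of the compounds shown alone.

Measured compounds:
compound 1, `Cc1c(C2CCCC2)c(=O)on1C(=O)N1CCCCC1` — 6 nM
compound 2, `Cc1c(CC(C)C)c(=O)on1C(=O)N1CCC(c2ccccc2)CC1` — 10 nM

Both were run in an assay (strain Wistar) for inhibition of Hormone-sensitive lipase (Rattus norvegicus), read by spectrophotometry; on this read-out higher numbers stand for weaker inhibition and lower numbers for stronger inhibition. Compound 1 gives 6 nM and compound 2 gives 10 nM. Compound 2 holds the higher of the two numbers, but its gap to compound 1 lies within the usual scatter, so the two results are read as equivalent rather than ordered. Among the compounds with values here, compound 1 and compound 2 differ in two places at once, so no single step between them can be separated out.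

Compound 3, `Cc1c(C2CCCC2)c(=O)on1C(=O)N1CCC(c2ccccc2)CC1`, has not yet been measured in this assay. Within the data shown here, it keeps the amide portion of compound 2 and changes only one group on the shared core: cyclopentyl in place of isobutyl on an aromatic carbon. Among the measured compounds shown here, no measured pair in this set isolates this exchange. For the measured compounds named here, the only guidance is that compound 1, which already carries cyclopentyl at the same place, gives 6 nM, and that compound 2 with isobutyl gives 10 nM; both sit at the same level.

Accordingly, compound 3 is expected to stay near that level, with a step of a 1.7-fold lower number from compound 2 to compound 3 (0.22 log units; within the scatter) from compound 2 that is not expected to exceed the scatter in either direction. The estimate for compound 3 in this assay is 6 nM, within a range of 2 nM to 18 nM.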

Compound 3, half-maximal inhibitory concentration: 24 nM
For compound 3 the middle estimate is 4.0-fold (0.60 log units) below the measured one; measured number outside the range, above it.
By their numbers in this assay, from the lowest: compounds 1 and 2 (each within the scatter of the next); then compound 3.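

In this assay, with the phenyl-bearing amide portion held fixed, cyclopentyl in place of isobutyl on the aromatic carbon gives a 2.4-fold higher number from compound 2 to compound 3 (0.38 log units; beyond the scatter), so this position does respond to the change of group, if only modestly, when that amide portion is present. Within the data shown here, with cyclopentyl held fixed, phenyl in place of hydrogen on a saturated ring carbon gives a 4.0-fold higher number from compound 1 to compound 3 (0.60 log units; beyond the scatter), the first single-place reading at that ring carbon, and it points toward weaker inhibition. Nothing available explains either step.

The compounds shown leave open whether the exchange of isobutyl for cyclopentyl reads the same when the saturated ring carbon bears hydrogen instead of phenyl, so the two steps cannot yet be judged as independent or linked. Also open, on these data alone, is how the aromatic carbon responds to a smaller group such as ethyl or a longer chain such as n-hexyl, and how the saturated ring carbon responds to a phenyl carrying a hydroxyl or a carboxylic acid.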